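The compounds below may be only part of what the source reports. "The series", "measured", "known", "first", "only" and "open" are said of these compounds alone.

Measured in a functional assay on BT-474 cells (Homo sapiens) for inhibition, read by MTT assay, with a stated time of 5 days; a lower number here means a stronger inhibitor, a higher number a weaker inhibitor:
compound 1 `Cc1cc(Nc2nc(NCc3ccc(Cl)cc3)nc3c2cnn3CC(C)(C)O)n[nH]1`: 16200 nM
compound 2 `Cc1cc(Nc2nc(NCc3ccc(F)cc3F)nc3c2cnn3C2CCOCC2)n[nH]1`: 2350 nM

Compound 2 has the lower of the two numbers, and its gap to compound 1 lies beyond the usual scatter. Compound 3 `Cc1cc(Nc2nc(NCc3ccc(F)cc3F)nc3c2cnn3CC(C)(C)O)n[nH]1` has not yet been measured. It is compound 2 with one change: 2-hydroxy-2-methylpropyl in place of oxan-4-yl on an aromatic nitrogen.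

Among the compounds with values here, no measured pair of compounds differs in just one place, so the size of this change in this assay cannot be read directly. The nearest evidence is compound 1, which carries the same 2-hydroxy-2-methylpropyl and gives 16200 nM, whereas compound 2 gives 2350 nM. However, compound 1 also differs from compound 2 in a second group on the shared core, so only part of that gap may belong to this change. A moderate move towards a weaker inhibitor is therefore expected, smaller than the whole gap, though a step within the scatter remains possible. The expected size of the change is a 2.6-fold higher number from compound 2 to compound 3 (0.41 log units; beyond the scatter). For compound 3, the estimated value is 6000 nM, with an expected range from 2000 nM to 18000 nM.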

Compound 3, half-maximal inhibitory concentration: 19400 nM
Compound 3: the middle estimate sits 3.2-fold (0.51 log units) below what was measured, outside the stated range (above it).
By their numbers in this assay, from the lowest: compound 2; then compounds 1 and 3 (each within the scatter of the next).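

In this assay, the exchange of oxan-4-yl for 2-hydroxy-2-methylpropyl on an aromatic nitrogen can now be read on its own: it gives an 8.3-fold higher number from compound 2 to compound 3 (0.92 log units; beyond the scatter), so the group at this position clearly matters in these cells, and the open-chain alcohol is the poorer of the two here. The second exchange, 2,4-difluorophenyl in place of 4-chlorophenyl, gives a 1.2-fold higher number from compound 1 to compound 3 (0.08 log units; within the scatter), so with 2-hydroxy-2-methylpropyl on the aromatic nitrogen this change leaves the number within the scatter. Nothing in the data given explains why oxan-4-yl gives the stronger inhibition of the two.

The compounds shown leave open which feature of the two groups carries the step, the ring of oxan-4-yl or the hydroxy group of the chain; a cyclohexyl or piperidin-4-yl ring, or a plain 2-methylpropyl chain without the hydroxy group, on the same nitrogen would help to separate these. Going by these compounds, it also remains open whether 4-chlorophenyl and 2,4-difluorophenyl would stay this close when oxan-4-yl sits on the aromatic nitrogen.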